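This account rests on a few compounds, and the source may have more. Where it says the series, first, only, none or still open, it means among the compounds named here.

The study gathers three compounds with a result or a note in an assay on isolated protein for inhibition of deoxyribonuclease-1 (Homo sapiens) (a higher number here means a weaker inhibitor, a lower number a stronger inhibitor), and one still to be tested. Compound 1 `CC(=O)Nc1cccc2c(=O)n(O)c(=O)[nH]c12` gives only a limit of the assay, > 100000 nM. Compound 2 `COc1nc(-c2cccs2)nc(C(=O)O)c1O` has no result in this assay, "not determined" (no result reported). Compound 3 `O=C(NCCO)c1nc(-c2cccs2)[nH]c(=O)c1O` likewise gives only a limit in this assay, > 100000 nM. Compound 3 therefore stands at the edge of what this assay reports, one other compound sits at the same edge and one carries no number at all, as summed up by the limit of > 100000 nM in this assay, at which 2 of the 3 values shown sit. For the measured compounds named here, no step between two measured compounds can be drawn from these entries.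

Compound 4 `O=C(Nc1cccnc1)c1nc(-c2cccs2)[nH]c(=O)c1O` differs from compound 3 in a single place: pyridin-3-yl in place of 2-hydroxyethyl on an amide-type nitrogen. Going by the values given here, nothing among the measured compounds shows what such a change does in this assay. Among the compounds with values here, with no measured step to lean on, the expected step is an at least 1.1-fold lower number from compound 3 to compound 4 (0.04 log units; that floor lies within the scatter), no change beyond the usual scatter, and a further limit remains the likelier outcome. Compound 4 is accordingly estimated at 90000 nM, within a range from 20000 nM to 400000 nM.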

Compound 4, half-maximal inhibitory concentration: > 100000 nM
Compound 4: no number, only a limit (the forecaster's own chance of this, stated with the estimate: 65%); middle value at least 1.1-fold (0.04 log units) away from the limit.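

For the compounds shown here, compound 3 and compound 4 both give only a limit in this assay, so no step between them can be read: the limit of > 100000 nM in this assay, at which 3 of the 4 values shown sit. The compounds shown leave open whether pyridin-3-yl and 2-hydroxyethyl on the amide-type nitrogen differ at all in this assay.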